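Ethoxy Gives Way to Nitro: Expectation for Compound 3

This account rests on a few compounds, and the source may have more. Where it says the series, first, only, none or still open, it means among the compounds named here.

Among the compounds with values here, compound 2 `CCOc1cc(/C=C2\SC(=S)NC2=O)ccc1OCN1C(=O)c2ccccc2C1=O` stands lowest of the two numbers measured so far in an assay on isolated protein for inhibition of Alpha glucosidase (Homo sapiens), read by spectrophotometry, with stated times of 15 min and 30 min (on this read-out higher numbers stand for weaker inhibition and lower numbers for stronger inhibition), where compound 2 gives 7720 nM. Within the data shown here, its only neighbour is compound 1 `COc1cc(/C=C2\SC(=S)NC2=O)ccc1OCN1C(=O)c2ccccc2C1=O`, which in this assay gives 16100 nM. Among the measured compounds shown here, the single measured step, a 2.1-fold lower number from compound 1 to compound 2 (0.32 log units; beyond the scatter), is a modest change and concerns only the lengthening of an alkoxy chain on the shared core.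

Compound 3 `O=C1NC(=S)S/C1=C\c1ccc(OCN2C(=O)c3ccccc3C2=O)c([N+](=O)[O-])c1` differs from compound 2 by nitro in place of ethoxy on an aromatic carbon, in words: nitro in place of ethoxy on an aromatic carbon. For the measured compounds named here, no measured step bears directly on this exchange. The step of a 2.1-fold lower number from compound 1 to compound 2 (0.32 log units; beyond the scatter) shows that altering the group on that aromatic carbon shifts the number only modestly, so a swap of one small group for another at the same position is expected to stay near compound 2, with wide uncertainty because nothing measured here involves a nitro group.

Compound 3 is therefore estimated to give 9000 nM in this assay, with a range from 3000 nM to 30000 nM. The expected step of a 1.2-fold higher number from compound 2 to compound 3 (0.07 log units; within the scatter) lies within the scatter.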

Compound 3, half-maximal inhibitory concentration: 6590 nM
Beside the measured number, compound 3's estimate is 1.4-fold (0.14 log units) above it, and the stated range covers the measured number.
By their numbers in this assay, from the lowest: compounds 3 and 2 (each within the scatter of the next); then compound 1.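

Until now this aromatic carbon had carried only alkoxy groups, and nitro, which enters with the same count of heavy atoms as the ethoxy it replaces but adds a double bond outside aromatic rings, gives in this assay a 1.2-fold lower number from compound 2 to compound 3 (0.07 log units; within the scatter) and so leaves the reading where ethoxy had it. Set against the shorter group, the same nitro gives a 2.4-fold lower number from compound 1 to compound 3 (0.39 log units; beyond the scatter) in that read-out, which places it with ethoxy on the far side of the scatter from methoxy and shows that the gain seen with ethoxy is not confined to alkoxy chains. No supporting data accompany these numbers to account for either step.

The compounds shown leave open how an amine, a carboxylic acid or an alkoxy chain longer than ethoxy would read at this carbon in this assay and whether any of them would move the number beyond the scatter from compound 3. Every compound shown also carries the same large group ortho to this carbon, so whether these steps would hold with a different group there remains unknown.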